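(tert-Butyl)sulfanyl on the chain of compound 1

The compounds below may be only part of what the source reports. "The series", "measured", "known", "first", "only" and "open" are said of these compounds alone.

This study follows a small series of compounds that share one core, tested in a functional assay for inhibition, with Rattus norvegicus as the target; on this read-out higher numbers stand for an effect only at larger amounts of compound and lower numbers for an effect already at smaller amounts. The starting point is compound 1 (`CSCC[C@H](NC(=O)c1ccc(CN[C@H](C)CC2CCCCC2)cc1-c1ccccc1C)C(=O)O`). In this assay compound 1 gives > 1000 nM, and this is a limit of the assay, not a measured number. Compound 2 (`CSCC[C@H](NC(=O)c1ccc(CN(CCC2CCCCC2)C(=O)OC(C)(C)C)cc1-c1ccccc1C)C(=O)O`), which has the same core but a different group on the amine nitrogen, gives 160 nM.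

The untested compound 3 (`CSCC[C@H](NC(=O)c1ccc(CN[C@H](CSC(C)(C)C)CC2CCCCC2)cc1-c1ccccc1C)C(=O)O`) differs from compound 1 in one place: (tert-butyl)sulfanyl in place of hydrogen on a saturated chain carbon, two bonds along the chain from an amine nitrogen. Put simply, (tert-butyl)sulfanyl stands in place of hydrogen on a saturated chain carbon, two bonds along the chain from an amine nitrogen. Within the data shown here, no measured step yet shows what this change does. Still, compound 2 at 160 nM shows that this core can give a real number in this assay, so a move towards lower numbers is expected rather than none. The expected step is an at least 8.3-fold lower number from compound 1 to compound 3 (0.92 log units; beyond the scatter), a clear gain in potency if it holds. For compound 3 the expected value is 120 nM, with an estimated range from 15 nM to 800 nM.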

Compound 3, half-maximal effective concentration: 2.8 nM
Beside the measured number, compound 3's estimate is 43-fold (1.63 log units) above it; measured number outside the range, below it.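

In this assay, putting (tert-butyl)sulfanyl in place of hydrogen on a saturated chain carbon, two bonds along the chain from an amine nitrogen, gives an at least 350-fold lower number from compound 1 to compound 3 (2.55 log units; beyond the scatter). Among these compounds, this is the first measured step at this position, and it shows that the chain carbon can carry this much larger group, with a large gain in potency rather than a loss. The size of the step is only a minimum, as compound 1 sits at a limit of the assay rather than at a measured number: the limit of > 1000 nM in this assay, at which 1 of the 3 values shown sits.

The compounds shown do not tell whether the gain depends on the sulfur atom, on the tert-butyl group or on both, and a methylsulfanyl group, a tert-butoxy group or a plain alkyl chain on this carbon would help to separate these possibilities. As far as these compounds go, it also remains open whether the same change would give a similar step in a compound carrying a tert-butyl carbamate on the amine nitrogen, the feature seen in compound 2.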